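From methylsulfanyl to pentyloxy on a shared core

The source may report more compounds than this note shows. Statements on the series, on what has been measured and on what is new or still open speak of the compounds shown alone.

- Compound 1 `CNc1nc(N)nc2c1ncn2/C=C1/CC1(CO)CO`: > 20000 nM
- Compound 2 `Nc1nc(OCc2ccccc2)c2ncn(/C=C3/CC3(CO)CO)c2n1`: > 20000 nM
- Compound 3 `CSc1nc(N)nc2c1ncn2/C=C1/CC1(CO)CO`: > 100000 nM

All three entries come from an ADME assay on CCRF-HSB-2 cells (Homo sapiens) for cytotoxicity, with a stated time of 7 days (on this read-out lower numbers stand for higher toxicity in this test and higher numbers for lower toxicity in this test), and each is a limit of the assay, not a number. Compound 3 stands at the limit of > 100000 nM in this assay, at which 1 of the 3 values shown sits. Compounds 1 and 2 stand at the limit of > 20000 nM in this assay, at which 2 of the 3 values shown sit.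

The next compound is compound 4 `CCCCCOc1nc(N)nc2c1ncn2/C=C1/CC1(CO)CO`, which carries pentyloxy in place of methylsulfanyl on an aromatic carbon. The nearest comparison exchanges benzyloxy for methylsulfanyl at the same place, and it is a step that the two limits leave unreadable from compound 2 to compound 3. The other two comparisons are a step that the two limits leave unreadable from compound 1 to compound 3 and a step that the two limits leave unreadable from compound 1 to compound 2. None of the three therefore gives a size to carry over.

Compound 2, whose benzyloxy group is the closest match to pentyloxy, has the limit > 20000 nM. Within the data shown here, that limit is the only guide here, so a modest move towards higher toxicity is expected, held with little confidence, and the result may again be only a limit. The expected change is an at least 3.3-fold lower number from compound 3 to compound 4 (0.52 log units; beyond the scatter). For compound 4 the estimated value is 30000 nM, with an expected range of 8000 nM to 100000 nM.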

Compound 4, half-maximal cytotoxic concentration: > 20000 nM
Compound 4 was reported as a limit; the forecaster's own chance of this, stated with the estimate: 70%; the middle value lies beyond the limit too.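

In this assay compound 4 gives > 20000 nM, which is a limit of the assay. Among these compounds, compound 1, compound 2 and compound 3 also stand only as limits, so no step from any of them to compound 4 can be read. The compounds shown leave open at what concentration any of the four becomes toxic to these cells, and whether the groups exchanged on the shared core differ at all.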